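A Hydroxy Group on the Ring of Compound 2

This account rests on a few compounds, and the source may have more. Where it says the series, first, only, none or still open, it means among the compounds named here.

Measured in a functional assay on NCI-H460 cells (Homo sapiens) for antiproliferative activity, read by MTT assay, with a stated time of 48 h; a higher number here means a weaker inhibitor, a lower number a stronger inhibitor:
- Compound 1 `Cc1ccc(Nc2ccc3c(c2)C(CCC(C)C)C(=O)N3)cc1`: 55300 nM
- Compound 2 `CC(C)CCC1C(=O)Nc2ccc(Nc3ccc(Cl)cc3)cc21`: 48700 nM
- Compound 3 `O=C1Nc2ccc(Nc3ccc(Cl)cc3)cc2C1CC1CCCCC1`: > 100000 nM

For compound 3, the reading of > 100000 nM is a limit of the assay and not a number. That leaves compound 2 with one numerical neighbour, compound 1, and the two lie within the scatter of each other: chloro in place of methyl on an aromatic carbon gives a 1.1-fold lower number from compound 1 to compound 2 (0.06 log units; within the scatter). Cyclohexyl in place of isobutyl on the chain gives an at least 2.0-fold higher number from compound 2 to compound 3 (0.31 log units; beyond the scatter).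

Compound 4 `CC(C)CCC1(O)C(=O)Nc2ccc(Nc3ccc(Cl)cc3)cc21` keeps the rest of compound 2 and carries hydroxy in place of hydrogen on a saturated ring carbon, two ring bonds from the ring nitrogen (hydroxy in place of hydrogen on a saturated ring carbon). Neither measured step makes this change, so they offer only a loose guide to its size, and no firm direction can be drawn from them. No change beyond the scatter is expected in this assay. The estimated result is a 1.1-fold lower number from compound 2 to compound 4 (0.03 log units; within the scatter). Compound 4 is expected at 45000 nM, with an estimated range of 15000 nM to 100000 nM.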

Compound 4, half-maximal inhibitory concentration: 25000 nM
Beside the measured number, compound 4's estimate is 1.8-fold (0.26 log units) above it; measured number inside the range.
By their numbers in this assay, from the lowest: compounds 4, 2 and 1 (each within the scatter of the next, the first and the last beyond it). At a limit, above all of these: compound 3.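

The earlier compounds shown here varied only the aromatic substituent and the chain, whereas compound 4 alters the saturated ring carbon itself, two ring bonds from the ring nitrogen. In this assay, hydroxy in place of hydrogen at this carbon gives a 1.9-fold lower number from compound 2 to compound 4 (0.29 log units; within the scatter), so this carbon can carry a group with a hydrogen-bond donor and acceptor without a shift beyond the scatter. Nothing measured here bears on why this step has the size it has.

Going by these compounds, whether a methoxy group, an amine or a fluorine on the same carbon would read alike remains open. So does what hydroxy would do at this carbon in compound 1, with its methyl, or in compound 3, with its cyclohexyl.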